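Adding a Nitro Group to Compound 1

The source may hold more compounds than are shown below. What is called first, only, known or untested is meant among the compounds shown, and "the series" means these compounds.

Going by the values given here, compound 1 `CCn1cc(-c2nc3ccccc3[nH]2)c(=O)c2cc(F)c(N3CCNCC3)nc21` gives 4100 nM in a functional assay on Bel-7402 cells (Homo sapiens) for cytotoxicity, read by MTT assay, with a stated time of 48 h (on this read-out lower numbers stand for stronger inhibition and higher numbers for weaker inhibition), and holds the lower of the only two numbers so far. Compound 2 `CCn1cc(-c2nc3ccccc3o2)c(=O)c2cc(F)c(N3CCNCC3)nc21` reads 16800 nM and so sits higher. Compound 3 `CCn1cc(-c2nc3ccc([N+](=O)[O-])cc3[nH]2)c(=O)c2cc(F)c(N3CCNCC3)nc21` is still unmeasured. It differs from compound 1 by nitro in place of hydrogen on an aromatic carbon. Among the compounds with values here, the only measured step (a 4.1-fold higher number from compound 1 to compound 2 (0.61 log units; beyond the scatter)) put 1,3-benzoxazol-2-yl in place of 1H-benzimidazol-2-yl. That is a different change, so it offers a rough size and no direction for adding nitro. In this assay a step of about that size or smaller, in either direction, is therefore expected (a 1.0-fold lower number from compound 1 to compound 3 (0.01 log units; within the scatter)). Compound 3 is estimated at 4000 nM within an expected range of 1000 nM to 16000 nM until the measurement arrives.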

Compound 3, half-maximal inhibitory concentration: 10800 nM
Beside the measured number, compound 3's estimate is 2.7-fold (0.43 log units) below it; low and high end bracket the measured number.
By their numbers in this assay, from the lowest: compound 1; then compounds 3 and 2 (each within the scatter of the next).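

The earlier step exchanged the whole 1H-benzimidazol-2-yl group, whereas this change keeps that group and adds nitro to an aromatic carbon of its six-membered ring of carbon only. In this assay, this single addition gives a 2.6-fold higher number from compound 1 to compound 3 (0.42 log units; beyond the scatter), so replacing hydrogen with nitro at this carbon weakens inhibition by more than the usual scatter. Nothing available explains this shift.

As far as these compounds go, whether the loss is specific to nitro or would follow from other groups at this carbon remains open, and an amine or a methoxy group in the same place would help separate those two readings. One substituent at one carbon also leaves open how the other carbons of this ring respond to substitution.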